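A few compounds are considered here, and "the series" means these few. Any claim that something is new, unique, unknown or untested is made for them only; others in the source may bear on it.

Measured compounds:
Compound 1, `CCOC(=O)N1CCC(=NNC(=O)c2ccc([N+](=O)[O-])cc2)CC1`, in a toxicity assay on BJ cells (Homo sapiens) for cytotoxicity, read by MTT assay, with a stated time of 24 h (on this read-out lower numbers stand for stronger inhibition and higher numbers for weaker inhibition), compound 1 gives > 400000 nM, a limit of the assay and not a number.
Compound 2, `O=C(NN=C1CC(c2ccccc2)NC(c2ccccc2)C1)c1ccc(Cl)cc1`, in this assay compound 2 gives > 400000 nM, again a limit and not a number.

Compound 2 thus stands at the ceiling of this assay, and its neighbour in the table stands there too; the two values show no order between them, and neither can be called more or less toxic than the other. Within the data shown here, both sit at the limit of > 400000 nM in this assay, at which 2 of the 2 values shown sit, so no measured step between any two compounds exists here.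

Compound 3, `O=C(NN=C1CC(c2ccccc2)NC(c2ccccc2)C1)c1ccc([N+](=O)[O-])cc1`, is the one not yet measured. It differs from compound 2 by nitro in place of chloro on an aromatic carbon, para to a large group; seen one bond further out, 4-chlorophenyl becomes 4-nitrophenyl. The shared core of compound 2 is kept. Among the measured compounds shown here, with no measured step to lean on, no shift beyond the usual scatter is expected in this assay in either direction. Compound 3 is therefore expected to give about 500000 nM, within 200000 nM to 2000000 nM, and the expected step that the limit leaves unreadable from compound 2 to compound 3 is essentially none.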

Compound 3, half-maximal inhibitory concentration: > 400000 nM
Compound 3 was reported as a limit; the forecaster's own chance of this, stated with the estimate: 85%; the middle value lies beyond the limit too.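

In this assay compound 3 gives > 400000 nM, a limit of the assay and not a number. No step from compound 2 to compound 3 can therefore be read: the limit of > 400000 nM in this assay, at which 3 of the 3 values shown sit.

The compounds shown leave open whether nitro in place of chloro on an aromatic carbon alters the toxicity to these cells at all.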